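Swapping a bromophenyl ring for thiophene: expected lipophilicity

This account rests on a few compounds, and the source may have more. Where it says the series, first, only, none or still open, it means among the compounds named here.

The measured compounds are:
compound 1, `CC1=C(C(=O)OCc2ccccn2)C(c2ccc(Br)cc2)C2=C(CCCC2=O)N1`, 2.42;
compound 2, `CC1=C(C(=O)OCc2cccnc2)C(c2ccccc2)C2=C(CCCC2=O)N1`, 2.35;
compound 3, `CC1=C(C(=O)OCc2cccnc2)C(c2ccc(Br)cc2)C2=C(CCCC2=O)N1`, 2.05.

All three were measured in a physicochemical assay for lipophilicity, measured as octanol-water partition; a lower number here means a more polar compound, a higher number a more lipophilic compound. Compound 1 has the highest of the three numbers, although compound 2 sits within the scatter of it, and only compound 3 lies beyond the scatter below it. Compound 4 is `CC1=C(C(=O)OCc2ccccn2)C(c2cccs2)C2=C(CCCC2=O)N1`, not yet measured. It differs from compound 1 in one place: thiophen-2-yl in place of 4-bromophenyl on a saturated ring carbon.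

Among the compounds with values here, no measured step removes this ring in the same way. The nearest guide is a number 0.30 log units lower from compound 2 to compound 3 (within the scatter), which concerns only the bromine and stays within the scatter. The other step, a number 0.37 log units lower from compound 1 to compound 3 (beyond the scatter), touches a different part of the shared core and does not bear on the change to compound 4. Because compound 2 and compound 3 differ by no more than a number 0.30 log units lower from compound 2 to compound 3 (within the scatter), the size of the step to compound 4 is hard to fix. A modest lowering is expected, with a wide range: for compound 4 the estimate is 2.05, between 1.55 and 2.55, a step of a number 0.37 log units lower from compound 1 to compound 4 (beyond the scatter).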

Compound 4, partition coefficient: 1.77
Compound 4: middle estimate off by 0.28 log units, on the high side; low and high end bracket the measured number.
By their numbers in this assay, from the lowest: compounds 4, 3, 2 and 1 (each within the scatter of the next, the first and the last beyond it).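

In this assay, within the data shown here, the ring on the saturated ring carbon turns out to matter more than the earlier compounds suggested: the only previous change there, a number 0.30 log units lower from compound 2 to compound 3 (within the scatter), was the exchange of bromo for hydrogen. Replacing the whole ring gives a number 0.65 log units lower from compound 1 to compound 4 (beyond the scatter), so this position can shift the number measurably when 4-bromophenyl gives way to thiophen-2-yl, a smaller ring that contains sulfur. Nothing available explains the size of this step.

The compounds shown do not separate the loss of the bromine from the change of ring, and they do not tell whether the same swap would give a similar step with the pyridin-3-yl group in the ester. From the compounds shown here alone, how this position would respond to a furan-2-yl group or to a phenyl ring carrying a carboxylic acid also remains open.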